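The source may hold more compounds than are shown below. What is called first, only, known or untested is meant among the compounds shown, and "the series" means these compounds.

Of the compounds shown here, three with a shared core have been tested in an assay on isolated protein for inhibition of ribosomal protein S6 kinase alpha-1 (Homo sapiens), read by mobility shift assay, tested at 30 uM; a lower number here means less inhibition, a higher number more inhibition at the concentration tested (going by the name of the read-out). Compound 1, `Cc1cc2[nH]nc(N)c2c(=O)[nH]1`, gives 6% in this assay. Compound 2, `Nc1n[nH]c2cc(-c3ccncc3)[nH]c(=O)c12`, gives 22% in this assay, and compound 3, `COc1ccc(-c2cc3[nH]nc(N)c3c(=O)[nH]2)cc1`, gives 7% in this assay. Compound 1 has the lowest of the three numbers: the number of compound 3 lies within the scatter of it, so nothing can be said about an order between them, while the number of compound 2 lies beyond the scatter above it.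

Compound 4, `CC(C)(C)c1cc2[nH]nc(N)c2c(=O)[nH]1`, is related to compound 1 by a single change: tert-butyl in place of methyl on an aromatic carbon. Among the compounds with values here, no measured pair with a comparable change is available, so the size of the step can only be guessed. Because compound 1 gives 6% in this assay and the change adds only carbon without any ring, donor or acceptor, the step of a number 2 percentage points higher from compound 1 to compound 4 (within the scatter) is expected to be small, not beyond the scatter, in no clear direction. For compound 4 the expected number in this assay is 8%, with a range from 0% to 20%.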

Compound 4, a percentage reported as inhibition, at one concentration (the size of the read-out at that concentration, not a potency): 22%
Compound 4: the middle estimate sits 14 percentage points below what was measured; measured number outside the range, above it.
By their numbers in this assay, from the lowest: compounds 1 and 3 (each within the scatter of the next); then compounds 2 and 4 (each within the scatter of the next).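

In this assay, within the data shown here, the step of a number 16 percentage points higher from compound 1 to compound 4 (beyond the scatter) is the first measured single change on the shared core, and it shows that the number can respond to what sits on this aromatic carbon. The change from methyl to tert-butyl adds only carbon, with no ring, hydrogen-bond donor or hydrogen-bond acceptor, yet that is enough to carry the number beyond the usual scatter at the one concentration tested. No measurement at hand explains why the number rises.

On these data alone, whether the number climbs steadily as the carbon group grows, or whether tert-butyl is a special case, stays open, and an ethyl or isopropyl group would speak to that. It is also unknown how this position would respond to a group that is not pure carbon, such as an amine or a carboxylic acid.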